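The source may hold more compounds than are shown below. What is called first, only, known or untested is meant among the compounds shown, and "the series" means these compounds.

Compound 1 `O=C(NO)c1ccc(NCCOc2ccc3cc2COC/C=C/COCc2cccc(c2)-c2ccnc(n2)N3)cc1` is the weaker of the two measured compounds: in an assay on Sf9 cells for inhibition of protein deacetylase HDAC6 (Homo sapiens), read by fluorescence, with a stated time of 2 h (a higher number here means a weaker inhibitor, a lower number a stronger inhibitor), compound 1 gives 395 nM, while compound 2 `O=C(NO)c1ccc(OCCOc2ccc3cc2COC/C=C/COCc2cccc(c2)-c2ccnc(n2)N3)cc1` gives 66 nM, a 6.0-fold lower number from compound 1 to compound 2 (0.78 log units; beyond the scatter). Compound 3 `O=C(O)CCCCCCC(=O)Nc1ccc(NCCOc2ccc3cc2COC/C=C/COCc2cccc(c2)-c2ccnc(n2)N3)cc1` differs from compound 1 by ((6-carboxyhexyl)carbonyl)amino in place of hydroxycarbamoyl on an aromatic carbon. Among the compounds with values here, no measured step touches this group; the only measured step, from compound 1 to compound 2, changes a different part, so it cannot guide the size of this change. The hydroxycarbamoyl group is removed entirely, so a large step to a higher number is expected, giving a 51-fold higher number from compound 1 to compound 3 (1.70 log units; beyond the scatter). Compound 3 is estimated at 20000 nM, with a range from 2000 nM to 200000 nM.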

Compound 3, half-maximal inhibitory concentration: 2600 nM
Compound 3: middle estimate off by 7.7-fold (0.89 log units), on the high side; the measured number falls inside the stated range.
By their numbers in this assay, from the lowest: compound 2; then compound 1; then compound 3.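

Replacing hydroxycarbamoyl with ((6-carboxyhexyl)carbonyl)amino on this aromatic carbon gives a 6.6-fold higher number from compound 1 to compound 3 (0.82 log units; beyond the scatter). Within the data shown here, this is the first measured change at this position, and it shows that inhibition remains measurable in this assay without the hydroxycarbamoyl group, with a modest step despite the much larger group entering. Nothing available explains the size of this step. The compounds shown leave open how much the chain's length and its carboxylic acid each contribute. A shorter chain, or a chain ending in an amine, would test this.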